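A few compounds are considered here, and "the series" means these few. Any claim that something is new, unique, unknown or untested is made for them only; others in the source may bear on it.

Measured compounds:
compound 1 `Cc1cc(C(=O)N2CCCCc3ccccc32)ccc1CNC(=O)Nc1ccccc1F` gives 30 nM
compound 2 `Cc1cc(C(=O)N2CCCCc3ccccc32)ccc1CNC(=O)NCC(=O)N1CCCCC1` gives 150 nM

Of the compounds shown here, two built on a shared core have been tested in a functional assay on HEK293 cells for agonist activity at Vasopressin V2 receptor (Homo sapiens), read by a luciferase reporter and cAMP accumulation; on this read-out lower numbers stand for an effect already at smaller amounts and higher numbers for an effect only at larger amounts of compound. For the measured compounds named here, compound 1 stands lowest of the two numbers with 30 nM; its only neighbour, compound 2, lies at 150 nM. Going by the values given here, the one measured step, a 5.0-fold higher number from compound 1 to compound 2 (0.70 log units; beyond the scatter), comes from putting ((piperidin-1-yl)carbonyl)methyl in place of 2-fluorophenyl on an amide-type nitrogen.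

Compound 3 `COC(=O)[C@@H]1CCCN1C(=O)NCc1ccc(C(=O)N2CCCCc3ccccc32)cc1C` has not yet been measured in this assay. Against compound 1 it differs thus: 2-(methoxycarbonyl)pyrrolidin-1-yl in place of (2-fluorophenyl)amino on a carbonyl carbon. As in compound 2, the 2-fluorophenyl group leaves and a saturated ring bearing a carbonyl enters, though here the ring sits directly on the carbonyl carbon and the hydrogen-bond donor of the (2-fluorophenyl)amino group is lost. Among the compounds with values here, the step of a 5.0-fold higher number from compound 1 to compound 2 (0.70 log units; beyond the scatter) is the only guide, and it was modest but beyond the scatter. A change of similar size and direction is therefore expected for compound 3, giving an estimated 4.0-fold higher number from compound 1 to compound 3 (0.60 log units; beyond the scatter). Compound 3 is expected to give about 120 nM, within 40 nM to 400 nM.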

Compound 3, half-maximal effective concentration: 100 nM
For compound 3 the middle estimate is 1.2-fold (0.08 log units) above the measured one; the range from low to high includes it.
By their numbers in this assay, from the lowest: compound 1; then compounds 3 and 2 (each within the scatter of the next).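

In this assay, a second, different replacement of (2-fluorophenyl)amino on this carbonyl carbon also gives a higher number than compound 1 (a 3.3-fold higher number from compound 1 to compound 3 (0.52 log units; beyond the scatter)), so among the three compounds shown, compound 1 with its aromatic 2-fluorophenyl group remains alone at the low end. The entering 2-(methoxycarbonyl)pyrrolidin-1-yl group has 0 hydrogen-bond donors, whereas the (((piperidin-1-yl)carbonyl)methyl)amino group of compound 2 keeps its amide hydrogen, yet the two compounds do not separate (a 1.5-fold lower number from compound 2 to compound 3 (0.18 log units; within the scatter)); at this position, therefore, losing that hydrogen carries no measurable penalty relative to compound 2. No measurement offered here accounts for either step.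

Going by these compounds, it remains open whether a carboxylic acid in place of the methyl ester of compound 3, or the opposite configuration at its stereocentre, would shift the number in this assay. Also open, on these data alone, is how much of the standing of compound 1 rests on the fluorine, which a plain phenylamino or a (2-chlorophenyl)amino group on the same carbonyl carbon would test.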